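Benzylic replacement in the cinnamate amide series

The source may report more compounds than this note shows. Statements on the series, on what has been measured and on what is new or still open speak of the compounds shown alone.

Compound 1 `COC(=O)/C=C/c1cccc(N(Cc2ccc(/C=C/c3ccc(F)cc3)cc2)C(=O)C(C)C)c1` is one of two compounds with a number in an assay on isolated protein with Bile acid receptor (Homo sapiens) as the target; a higher number here means that more compound is needed for the effect, a lower number that less compound is needed. In this assay compound 1 gives 120 nM, the higher of the two numbers, while compound 2 `COC(=O)/C=C/c1cccc(N(Cc2ccc(-c3ccc(OC)cc3)cc2)C(=O)C2CCCCC2)c1` gives 89 nM; the gap between compound 1 and compound 2 lies within the scatter, so the two read the same. Among the compounds with values here, compound 2 also carries a different amide and a different aromatic substituent, so no single-change step is available between any two measured compounds.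

Compound 3 `COC(=O)/C=C/c1cccc(N(Cc2ccc(-c3c(OC)cccc3OC)cc2)C(=O)C(C)C)c1` is not yet measured. It differs from compound 1 in one place: 2,6-dimethoxyphenyl in place of 2-(4-fluorophenyl)ethenyl on an aromatic carbon. The isobutyryl amide and the cinnamate ester of the shared core are kept.

Compound 2 shows that a directly attached methoxyphenyl on the same aromatic carbon is compatible with a number close to that of compound 1: compound 1 gives 120 nM and compound 2 gives 89 nM. The step from compound 1 to compound 3 is therefore expected to be small, a 1.3-fold higher number from compound 1 to compound 3 (0.10 log units; within the scatter), with no direction that can be called beyond the scatter. For compound 3 the estimate in this assay is 150 nM, within a range of 50 nM to 500 nM.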

Compound 3, half-maximal effective concentration: 95 nM
Estimate against measurement, compound 3: 1.6-fold (0.20 log units) above, and the stated range covers the measured number.
By their numbers in this assay, from the lowest: compounds 2, 3 and 1 (each within the scatter of the next).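

Within the data shown here, the first single-change step puts 2,6-dimethoxyphenyl in place of 2-(4-fluorophenyl)ethenyl on this aromatic carbon, and this assay reads it as a 1.3-fold lower number from compound 1 to compound 3 (0.10 log units; within the scatter), so compound 1 and compound 3 read the same. With the isobutyryl amide and the cinnamate ester kept, this position therefore accepts the loss of the double bond outside aromatic rings and of the fluorine, and the arrival of hydrogen-bond acceptors where the leaving group has none, without a step beyond the scatter. No measurement shown bears on why these two groups give matching numbers.

The compounds shown leave open how a group of a different kind at this aromatic carbon, such as an aminomethyl group or a carboxylic acid, would read in this assay. Also open, as far as these compounds go, is whether the same exchange stays within the scatter when the isobutyryl amide is replaced by the amide of compound 2, and whether the position behaves alike with a carboxylic acid in place of the methyl ester.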